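The source may report more compounds than this note shows. Statements on the series, on what has been measured and on what is new or still open speak of the compounds shown alone.

Working notes on the series. The shared core of compound 1 `Cc1ccccc1CNc1nn(-c2ccc(F)cc2F)cc1CNCCN1CCN(C)CC1` carries a 2-methylphenylmethyl amine and a 2,4-difluorophenyl group; compound 2 `Cc1ccccc1-c1nn(C(C)C)cc1CNCCN1CCN(C)CC1` puts a 2-methylphenyl directly on the core and an isopropyl on the aromatic nitrogen; compound 3 `CCCN1CCC(CNCc2cn(-c3ccc([N+](=O)[O-])cc3)nc2-c2ccc(OC(F)(F)F)cc2)CC1` is a further relative with a 4-(trifluoromethoxy)phenyl on the core and a nitrophenyl on the aromatic nitrogen. In an ADME assay on Huh-7 cells (Homo sapiens) for cytotoxicity (a higher number here means that more compound is tolerated, a lower number that less compound is tolerated), compound 1 gives only a limit, > 20000 nM. Compound 2 likewise reaches only the limit, > 20000 nM. Compound 3 gives a number in this assay, 18000 nM. Compound 2 therefore stands at the limit of > 20000 nM in this assay, at which 2 of the 3 values shown sit, with no number of its own. The step to compound 4 `Cc1ccccc1-c1nn(-c2ccc(OC(F)(F)F)cc2)cc1CNCCN1CCN(C)CC1` is 4-(trifluoromethoxy)phenyl in place of isopropyl on an aromatic nitrogen. Going by the values given here, no step between measured compounds is available to size the change; the three results lie so close together that no movement beyond the scatter is expected, so the step from compound 2 to compound 4 is estimated as a number no higher from compound 2 to compound 4 (the limit leaves the size open). In this assay compound 4 is expected near 20000 nM, within 9000 nM to 40000 nM.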

Compound 4, half-maximal cytotoxic concentration: 17000 nM
For compound 4 the middle estimate is 1.2-fold (0.07 log units) above the measured one; low and high end bracket the measured number.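

In this assay, 4-(trifluoromethoxy)phenyl in place of isopropyl on an aromatic nitrogen gives an at least 1.1-fold lower number from compound 2 to compound 4 (0.07 log units; that floor lies within the scatter), the only step shown at this position. The exchange brings in an aromatic ring and 11 heavy atoms where isopropyl had 3, and compound 4 still gives a number in this assay, so the position accepts this aryl group without a printed move beyond the scatter. Compound 2 has only a limit and no number of its own, so the true size of the step stays open: the limit of > 20000 nM in this assay, at which 2 of the 4 values shown sit.

Going by these compounds, whether a basic amine, a carboxylic acid or a longer alkyl chain on this aromatic nitrogen would read differently in this assay remains open. Also open, on these data alone, is whether the same exchange would read alike with a group other than 2-methylphenyl on the shared core.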